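The source may report more compounds than this note shows. Statements on the series, on what has been measured and on what is new or still open speak of the compounds shown alone.

Measured so far:
- compound 1, `COc1cc(N(C)CCN(C)C)c(NC(=O)/C=C\C(C)C)cc1Nc1nccc(-c2cn(C)c3ccccc23)n1`: 1820 nM
- compound 2, `C=CC(=O)Nc1cc(Nc2nccc(-c3cn(C)c4ccc(F)cc34)n2)c(OC)cc1N(C)CCN(C)C`: 254 nM
- compound 3, `CC/C=C\C(=O)Nc1cc(Nc2nccc(-c3cn(C)c4ccc(F)cc34)n2)c(OC)cc1N(C)CCN(C)C`: 2600 nM

Compound 3 gives the highest number of the three in a functional assay on NCI-H1975 cells (Homo sapiens) for antiproliferative activity, read by MTT assay, with a stated time of 72 h; on this read-out lower numbers stand for stronger inhibition and higher numbers for weaker inhibition. Its nearest neighbour is compound 1, whose value lies within the scatter of that of compound 3; the gap to compound 2 is far beyond the scatter, as the lengthening of the chain on the carbonyl carbon brought a 10-fold higher number from compound 2 to compound 3 (1.01 log units; beyond the scatter).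

Compound 4, `COc1cc(N(C)CCN(C)C)c(NC(=O)/C=C\C(C)C)cc1Nc1nccc(-c2cn(C)c3ccc(F)cc23)n1`, differs from compound 3 by methyl in place of hydrogen on a saturated chain carbon bound to a double-bonded chain carbon and a saturated chain carbon. Among the measured compounds shown here, no measured pair shows exactly this change. For the measured compounds named here, the only step that bears on the chain on the carbonyl carbon is the one from vinyl to but-1-en-1-yl, which raised the number strongly. Compound 1 already carries the 3-methylbut-1-en-1-yl chain of compound 4, and its value and that of compound 3 sit within the scatter of each other. The expected step is therefore a 1.2-fold lower number from compound 3 to compound 4 (0.07 log units; within the scatter), no shift beyond the scatter in this assay. Compound 4 is estimated at 2200 nM in this assay, with a range from 800 nM to 6000 nM.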

Compound 4, half-maximal inhibitory concentration: 7360 nM
Compound 4: the middle estimate sits 3.3-fold (0.52 log units) below what was measured; measured number above the stated range.
By their numbers in this assay, from the lowest: compound 2; then compounds 1 and 3 (each within the scatter of the next); then compound 4.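

In this assay, adding the methyl on a saturated chain carbon bound to a double-bonded chain carbon and a saturated chain carbon has a measurable effect, with a 2.8-fold higher number from compound 3 to compound 4 (0.45 log units; beyond the scatter). The 3-methylbut-1-en-1-yl chain therefore extends the loss seen with but-1-en-1-yl, and its full step from the vinyl compound is a 29-fold higher number from compound 2 to compound 4 (1.46 log units; beyond the scatter). Among the compounds shown here, the same chain also gives the first reading of fluoro in place of hydrogen on an aromatic carbon, with a 4.0-fold higher number from compound 1 to compound 4 (0.61 log units; beyond the scatter), so fluoro does not improve the number in this pair.

No supporting data are available to explain these steps. Going by these compounds, it remains open whether fluoro gives a similar step with a vinyl group on the carbonyl carbon, and how a dimethylamino group on the same saturated chain carbon would read.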